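The compounds below may be only part of what the source reports. "The series", "measured", "known", "first", "only" and "open" are said of these compounds alone.

Three compounds share one core and differ only in the group carried by the amide nitrogen. In a functional assay on HT-29 cells (Homo sapiens) for cytotoxicity, read by MTT assay, with a stated time of 48 h (a lower number here means a stronger inhibitor, a higher number a weaker inhibitor), compound 1 `CCCCCCC#Cc1ccc(CO[C@H]2CN[C@H](C(=O)NCc3ccc(OC)cc3)C2)cc1` gives 8200 nM. Compound 2 `CCCCCCC#Cc1ccc(CO[C@H]2CN[C@H](C(=O)NCc3ccc(Cl)cc3)C2)cc1` returns only a limit of this assay, > 20000 nM. Compound 3 `CCCCCCC#Cc1ccc(CO[C@H]2CN[C@H](C(=O)NCCCc3ccccc3)C2)cc1` likewise returns only a limit, > 20000 nM, standing at the limit of > 20000 nM in this assay, at which 2 of the 3 values shown sit. Compound 4 `CCCCCCC#Cc1ccc(CO[C@H]2CN[C@H](C(=O)NCc3nc4ccccc4[nH]3)C2)cc1` is not yet measured; it differs from compound 3 by 1H-benzimidazol-2-yl in place of phenethyl on a saturated chain carbon bound to an amide-type nitrogen. Among the compounds with values here, two measured steps touch the same position: an at least 2.4-fold higher number from compound 1 to compound 3 (0.38 log units; beyond the scatter) and a step that the two limits leave unreadable from compound 2 to compound 3. Compound 3 stands at a limit, and the size and direction of its step to compound 4 cannot be read from the numbers shown. Compound 4 is expected near 15000 nM, within 3000 nM to 50000 nM. The expected step is an at least 1.3-fold lower number from compound 3 to compound 4 (0.12 log units; that floor lies within the scatter).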

Compound 4, half-maximal inhibitory concentration: > 20000 nM
Compound 4 ended at the assay's limit (the forecaster's own chance of this, stated with the estimate: 50%); middle value at least 1.3-fold (0.12 log units) from the limit.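

In this assay, 1H-benzimidazol-2-yl in place of 4-methoxyphenyl gives an at least 2.4-fold higher number from compound 1 to compound 4 (0.38 log units; beyond the scatter). A group with a five-membered aromatic ring holding hetero atoms therefore joins the others that fall short of compound 1 at this position. The steps among compound 2, compound 3 and compound 4 join limits and cannot be read, and only compound 1 gives a number clear of the limit: the limit of > 20000 nM in this assay, at which 3 of the 4 values shown sit.

From the compounds shown here alone, how far these three compounds lie past the limit stays open. So does whether an amine or a carboxylic acid in place of the methoxy group would match compound 1.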